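Ring-nitrogen substituent exchange from compound 2 to compound 4

A few compounds are considered here, and "the series" means these few. Any claim that something is new, unique, unknown or untested is made for them only; others in the source may bear on it.

Three measured compounds share one core and differ only in the group on the ring nitrogen. In a functional assay on isolated protein for inhibition of Glucose-dependent insulinotropic receptor (Rattus norvegicus), read by HTRF and cAMP accumulation (a higher number here means a larger maximal response, a lower number a smaller maximal response), compound 1 `Cc1nc(S(C)(=O)=O)ccc1Oc1ncnc(OC2CCN(C(=O)OC3CCC3)CC2)c1F` gives 81%. In this assay compound 2 `Cc1nc(S(C)(=O)=O)ccc1Oc1ncnc(OC2CCN(C(=O)O[C@@H](C)C(F)(F)F)CC2)c1F` gives 80%, and in this assay compound 3 `Cc1nc(S(C)(=O)=O)ccc1Oc1ncnc(OC2CCN(C(=O)SC(C)C)CC2)c1F` gives 81%. On these numbers compound 2 sits alongside both neighbours: a number 1 percentage points lower from compound 1 to compound 2 (within the scatter), and a number 1 percentage points higher from compound 2 to compound 3 (within the scatter). The remaining pair shows no change at the digits printed from compound 1 to compound 3 (within the scatter). Compound 4 `Cc1nc(S(C)(=O)=O)ccc1Oc1ncnc(OC2CCN(C(=S)OC(C)C)CC2)c1F` has not been measured in this assay. It differs from compound 2 as follows: a group of 6 heavy atoms (4 carbon, 1 oxygen, 1 sulfur; no ring) in place of a group of 9 heavy atoms (4 carbon, 2 oxygen, 3 fluorine; no ring), on an amine nitrogen in a ring. The three known exchanges at this ring nitrogen, a cyclobutyl for a 1-(trifluoromethyl)ethyl, a cyclobutyloxy for an isopropylsulfanyl, and a 1-(trifluoromethyl)ethoxy for an isopropylsulfanyl, all stayed within the scatter, so the largest response in this assay is expected to hold steady. The expected step is a number 1 percentage points higher from compound 2 to compound 4 (within the scatter). For compound 4 the estimated value in this assay is 81%, with a range from 70% to 92%.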

Compound 4, largest response reached (reported as efficacy), in percent of the reference or control that the assay uses: 47%
Estimate against measurement, compound 4: 34 percentage points above; the whole stated range lies above it.
By their numbers in this assay, from the lowest: compound 4; then compounds 2, 1 and 3 (each within the scatter of the next).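

In this assay, the group on the amine nitrogen in the ring turns out not to be freely exchangeable: a number 33 percentage points lower from compound 2 to compound 4 (beyond the scatter), and a number 34 percentage points lower from compound 1 to compound 4 (beyond the scatter). The group of compound 3 has the same heavy atoms as that of compound 4, yet a number 34 percentage points lower from compound 3 to compound 4 (beyond the scatter), so atom composition alone does not set the response; the two groups differ in that sulfur sits in the double bond of compound 4 and links the isopropyl group in compound 3. Nothing in hand explains this loss.

Still open, going by these compounds, is whether the loss follows the double-bonded sulfur when cyclobutyloxy or 1-(trifluoromethyl)ethoxy takes the place of the isopropoxy group. Also open, on these data alone, is how isopropoxy on a plain carbonyl carbon, or an amine on that carbon, would behave.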